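Chain Extension on the Amide and Liver-Cell Inhibition

A few compounds are considered here, and "the series" means these few. Any claim that something is new, unique, unknown or untested is made for them only; others in the source may bear on it.

Compound 1 `COc1ccc(Nc2nc(Oc3cccc(NC(=O)C=C(C)C)c3)c3sccc3n2)cc1` gives 48900 nM in an ADME assay on L02 cells (Homo sapiens) for inhibition, read by MTT assay, with a stated time of 72 h; on this read-out higher numbers stand for weaker inhibition and lower numbers for stronger inhibition.
Compound 2 `C=CC(=O)Nc1cccc(Oc2nc(Nc3cccc(OC)c3)nc3ccsc23)c1` gives 30300 nM in this assay.
For compound 3 `COc1cccc(Nc2nc(Oc3cccc(NC(=O)C=C(C)C)c3)c3sccc3n2)c1` the result in this assay is recorded as "not determined" (no result reported), so no number is available for it.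

On the two numbers available, compound 2 and compound 1 lie within the usual scatter of one another, so neither can be called the stronger or weaker inhibitor. Compound 4 `CC/C=C/C(=O)Nc1cccc(Oc2nc(Nc3cccc(OC)c3)nc3ccsc23)c1` is derived from compound 2 by a single change, (but-1-en-1-yl in place of vinyl on a carbonyl carbon), that is, but-1-en-1-yl in place of vinyl on a carbonyl carbon. Among the measured compounds shown here, no pair of measured compounds differs in only one place, so no measured step guides the expectation. The expected step is a 1.3-fold higher number from compound 2 to compound 4 (0.12 log units; within the scatter), if anything toward weaker inhibition, though it may well fall within the scatter. Compound 4 is therefore estimated at 40000 nM, within 15000 nM to 100000 nM.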

Compound 4, half-maximal inhibitory concentration: > 50000 nM
Compound 4: no number, only a limit; the forecaster's own chance of this, stated with the estimate: 20%; middle value at least 1.2-fold (0.09 log units) from the limit.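

Among the compounds shown here, this is the first step measured at this position, the carbonyl carbon of the amide: in this assay, but-1-en-1-yl in place of vinyl gives an at least 1.6-fold higher number from compound 2 to compound 4 (0.21 log units; that floor lies within the scatter). For compound 4 the entry is a limit of the assay and not a number: the limit of > 50000 nM in this assay, at which 1 of the 4 values shown sits. The step therefore has only a floor, and with that floor inside the scatter, the change is not shown to weaken inhibition.

On these data alone, the true size of the step remains open. So does how a longer chain, or an amine on the chain, would read at this position.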